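Alkyl variation on the lactam ring carbon of the core

The source may hold more compounds than are shown below. What is called first, only, known or untested is meant among the compounds shown, and "the series" means these compounds.

In an ADME assay on cells for inhibition of cytochrome P450 11B1, mitochondrial (Homo sapiens), read by HTRF (a lower number here means a stronger inhibitor, a higher number a weaker inhibitor), the measured compounds stand as follows.
compound 1 (`CC(=O)N[C@@H]1CCCc2c1cncc2N1C(=O)c2ccc(Cl)cc2[C@@H]1C1CC1`): > 30000 nM, a limit of the assay and not a number.
compound 2 (`CC(=O)N[C@@H]1CCCc2c1cncc2N1C(=O)c2ccc(Cl)cc2[C@@H]1C`): 81 nM.
compound 3 (`CC(=O)N[C@@H]1CCCc2c1cncc2N1Cc2cc(Cl)ccc2C1=O`): 2330 nM.

Compound 3 gives the highest of the two numbers; the step of a 29-fold higher number from compound 2 to compound 3 (1.46 log units; beyond the scatter) separates it from compound 2, and compound 1 sits only at a limit.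

Compound 4 (`CC[C@H]1c2cc(Cl)ccc2C(=O)N1c1cncc2c1CCC[C@H]2NC(C)=O`) changes compound 3 by ethyl in place of hydrogen on a saturated ring carbon. Among the compounds with values here, the steps that bear on it are a 29-fold higher number from compound 2 to compound 3 (1.46 log units; beyond the scatter), an at least 12-fold lower number from compound 1 to compound 3 (1.10 log units; beyond the scatter) and an at least 370-fold lower number from compound 1 to compound 2 (2.56 log units; beyond the scatter): methyl gives a strong drop in number, cyclopropyl a strong rise, so ethyl could fall on either side. A moderate improvement is expected, a 4.7-fold lower number from compound 3 to compound 4 (0.67 log units; beyond the scatter), with a wide range. Compound 4 is estimated at 500 nM, between 60 nM and 10000 nM.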

Compound 4, half-maximal inhibitory concentration: 3630 nM
For compound 4 the middle estimate is 7.3-fold (0.86 log units) below the measured one; the range from low to high includes it.
By their numbers in this assay, from the lowest: compound 2; then compounds 3 and 4 (each within the scatter of the next). At a limit, above all of these: compound 1.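

On this saturated ring carbon the effect of methyl does not extend to ethyl: a 45-fold higher number from compound 2 to compound 4 (1.65 log units; beyond the scatter), whereas a 1.6-fold higher number from compound 3 to compound 4 (0.19 log units; within the scatter), so ethyl stays within the scatter of hydrogen. Ethyl still stands apart from cyclopropyl, with an at least 8.2-fold lower number from compound 1 to compound 4 (0.91 log units; beyond the scatter). That step has only one measured end, since compound 1 gives a limit and not a number: the limit of > 30000 nM in this assay, at which 1 of the 4 values shown sits.

From the compounds shown here alone, whether a hydroxymethyl or methoxymethyl group on this carbon would stay close to compound 2 remains open. So does the outcome for a longer chain such as propyl, or for the opposite configuration at this carbon.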